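A few compounds are considered here, and "the series" means these few. Any claim that something is new, unique, unknown or untested is made for them only; others in the source may bear on it.

In an ADME assay on microsomes from liver (Rattus norvegicus) for metabolic stability (a lower number here means that the compound disappears faster, a higher number that the compound lasts longer), compound 1 `Cc1cccc(NC(=O)c2nn(C)c(-c3ccc(F)cc3)c2C)n1` gives 0.933 h and compound 2 `Cc1cccc(NC(=O)c2nn(C)c(-c3ccc(F)cc3F)c2C)n1` gives 1.27 h, so the two sit level within the scatter. Compound 3 `Cc1cccc(NC(=O)c2nn(C)c(-c3ccc(C(F)(F)F)cc3)c2C)n1` shows > 5 h, which is a limit of the assay and not a number. Compound 4 `Cc1c(C(=O)Nc2ccc(Cl)cn2)nn(C)c1-c1ccc(F)cc1` differs from compound 1 by 5-chloropyridin-2-yl in place of 6-methylpyridin-2-yl on an amide-type nitrogen. Both measured steps lie elsewhere in the molecule, so they give only a rough sense of scale: a 1.4-fold higher number from compound 1 to compound 2 (0.13 log units; within the scatter), and an at least 5.3-fold higher number from compound 1 to compound 3 (0.72 log units; beyond the scatter). Only the second went beyond the scatter, and it went upward. A modest rise in this assay is therefore expected, estimated as a 1.6-fold higher number from compound 1 to compound 4 (0.21 log units; within the scatter). The expected half-life of compound 4 is 1.5 h, within a range of 0.6 h to 4 h.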

Compound 4, half-life: 3.65 h
Compound 4: the middle estimate sits 2.4-fold (0.39 log units) below what was measured, and the stated range covers the measured number.
By their numbers in this assay, from the lowest: compounds 1 and 2 (each within the scatter of the next); then compound 4. At a limit, above all of these: compound 3.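

In this assay, placing 5-chloropyridin-2-yl on the amide-type nitrogen in place of 6-methylpyridin-2-yl gives a 3.9-fold higher number from compound 1 to compound 4 (0.59 log units; beyond the scatter). The half-life therefore responds to a change at this position, and not only to the changes elsewhere in the molecule seen earlier. No measurement shown explains this rise.

Going by these compounds, the swap removes a methyl group and adds a chlorine at once, so their separate contributions stay unknown. Also open, on these data alone, is how a plain pyridin-2-yl, or a nitrile or methoxy group in place of the chlorine, would behave.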